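Shortening the side chain to a hydroxymethyl group

This account rests on a few compounds, and the source may have more. Where it says the series, first, only, none or still open, it means among the compounds named here.

Compound 2 `O=C(C[C@H](NC(=O)c1cc2ccccc2cn1)C(=O)OCc1ccccc1)OCc1ccccc1` gives the higher of the two numbers recorded so far. In a functional assay on the whole organism (CCRF S-180 cells, Mus musculus) for inhibition, in a xenograft, with stated times of 7 days and 24 h, at a dose of 100 umol/kg by the intraperitoneal route (on this read-out lower numbers stand for less inhibition and higher numbers for more inhibition at the one dose given (going by the name of the read-out)), compound 2 gives 37.5%, while compound 1 `O=C(CC[C@H](NC(=O)c1cc2ccccc2cn1)C(=O)OCc1ccccc1)OCc1ccccc1` gives 25.2%. Within the data shown here, the one measured step, a number 12.3 percentage points higher from compound 1 to compound 2 (beyond the scatter), shows that removing a methylene from the side chain raised the read-out by a modest amount.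

Compound 3 `O=C(N[C@@H](CO)C(=O)OCc1ccccc1)c1cc2ccccc2cn1` takes this chain one stage further: hydroxy in place of benzyloxycarbonyl on a saturated chain carbon, two bonds along the chain from an amide-type nitrogen and a carbonyl carbon. Among the measured compounds shown here, no measured step covers the loss of the benzyloxycarbonyl group itself; the step from compound 1 to compound 2 only shows that a shorter side chain did not lower the read-out, and it is the only guide available. The direction of the change from compound 2 to compound 3 therefore cannot be read from the data with confidence, and a step of either sign within or just beyond the scatter seems plausible.

On that basis, compound 3 is expected to give about 30% in this assay, within a range from 10% to 50%, which corresponds to an estimated step of a number 7.5 percentage points lower from compound 2 to compound 3 (within the scatter).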

Compound 3, a percentage reported as inhibition, in the whole organism at one dose (the size of the read-out at that dose, not a potency): 40.4%
The estimate for compound 3 lay 10.4 percentage points below the measured number, and the stated range covers the measured number.
By their numbers in this assay, from the lowest: compound 1; then compounds 2 and 3 (each within the scatter of the next).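

In this assay, hydroxy in place of benzyloxycarbonyl on this saturated chain carbon gives a number 2.9 percentage points higher from compound 2 to compound 3 (within the scatter), so the read-out at the one dose holds even when this ester group and its aromatic ring are gone. Hydroxy in place of (benzyloxycarbonyl)methyl at the same carbon gives a number 15.2 percentage points higher from compound 1 to compound 3 (beyond the scatter), and this step lies beyond the scatter, as does a number 12.3 percentage points higher from compound 1 to compound 2 (beyond the scatter), which sets compound 1 apart from the two compounds with the shorter side chains while compound 2 and compound 3 cannot be told apart here. Nothing available bears on the cause of these numbers.

The compounds shown leave open whether an amine, a carboxylic acid or a plain methyl group on this carbon would keep the read-out at the level of compound 2 and compound 3, and so whether the hydroxy group itself matters at all. They also leave open what happens when the benzyloxycarbonyl group that compound 3 still carries gives way to a carboxylic acid, and whether the pattern holds at any other dose.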